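A few compounds are considered here, and "the series" means these few. Any claim that something is new, unique, unknown or untested is made for them only; others in the source may bear on it.

Compound 3 `CCN(CC)S(=O)(=O)c1ccc(S(=O)(=O)N2CCC[C@@H](C(=O)NC3COC3)C2)cc1` stands at the weak end of the series: in a functional assay on MIA PaCa-2 cells (Homo sapiens) for inhibition, read by MTT assay, with a stated time of 7 days (on this read-out higher numbers stand for weaker inhibition and lower numbers for stronger inhibition), compound 3 gives 2340 nM, the highest of the three numbers. Compound 1 `O=C([C@@H]1CCCN(S(=O)(=O)c2ccc(S(=O)(=O)C3CCC3)cc2)C1)N1CCC(F)(F)CC1` gives 9 nM in this assay, and compound 2 `CCC(CC)S(=O)(=O)c1ccc(S(=O)(=O)N2CCC[C@@H](C(=O)N3CCC(F)(F)CC3)C2)cc1` gives 13 nM. Going by the values given here, the only single-point step among the measured compounds is a 1.4-fold higher number from compound 1 to compound 2 (0.16 log units; within the scatter), which concerns the sulfonyl sulfur and not the carbonyl end where compound 4 `CCN(CC)S(=O)(=O)c1ccc(S(=O)(=O)N2CCC[C@@H](C(=O)N3CC[C@@H](OC)C3)C2)cc1` differs from compound 3.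

That difference is 3-methoxypyrrolidin-1-yl in place of (oxetan-3-yl)amino on a carbonyl carbon. Among the compounds with values here, no measured pair isolates this change, so nothing in the data tells its size directly. Compounds 1 and 2 share neither end of compound 3 exactly, so the gap between the number of compound 3, 2340 nM, and the number of compound 1, 9 nM, cannot be assigned to one place. The step from compound 1 to compound 2 is within the scatter and bears on a different position, so it gives no guidance here.

On this footing he expects a step of a 12-fold lower number from compound 3 to compound 4 (1.07 log units; beyond the scatter) in this assay, towards a lower number, but with wide uncertainty. His estimate for compound 4 in this assay is 200 nM, with a range from 20 nM to 2000 nM.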

Compound 4, half-maximal inhibitory concentration: 3910 nM
Compound 4: the middle estimate sits 20-fold (1.29 log units) below what was measured; the whole stated range lies below it.
By their numbers in this assay, from the lowest: compounds 1 and 2 (each within the scatter of the next); then compounds 3 and 4 (each within the scatter of the next).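

In this assay the carbonyl carbon now has its first measured pair: 3-methoxypyrrolidin-1-yl in place of (oxetan-3-yl)amino gives a 1.7-fold higher number from compound 3 to compound 4 (0.22 log units; within the scatter) and so the two groups cannot be told apart on this read-out. The exchange swaps a four-membered non-aromatic ring for a five-membered one and takes the count of hydrogen-bond donors from one to none, adds a defined stereocentre, and still leaves the number within the scatter, with the rest of the molecule unchanged. No supporting measurement bears on this result.

Whether the large gap to compounds 1 and 2 belongs to the sulfonyl end or to the carbonyl end stays open, since no pair shown differs from compound 3 or compound 4 at one of those ends alone. Also open, as far as these compounds go, is how this position would respond to a group of a different kind on the carbonyl carbon, such as a primary amine on a short chain, a carboxylic acid on a longer chain, or a simple dimethylamino group.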